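A few compounds are considered here, and "the series" means these few. Any claim that something is new, unique, unknown or untested is made for them only; others in the source may bear on it.

Measured so far, in a physicochemical assay for solubility, measured as kinetic solubility; a lower number here means a less soluble compound, a higher number a more soluble compound:
- compound 1, `C[C@H](NC(=O)[C@H]1CCCC[C@@H]1c1ccccc1)c1ccccc1`, gives 57000 nM
- compound 2, `O=C(N[C@@H](CO)c1ccccc1)[C@H]1CCCC[C@@H]1c1ccccc1`, gives 455000 nM
- compound 3, `O=C(N[C@@H](CO)c1ccccc1)[C@H]1CC(F)(F)CC[C@@H]1c1ccccc1`, gives 332000 nM

Compound 1 differs from compound 2 by hydrogen in place of hydroxy on a saturated chain carbon, two bonds along the chain from an amide-type nitrogen and an aromatic carbon, and this change gave an 8.0-fold lower number from compound 2 to compound 1 (0.90 log units; beyond the scatter). Compound 3 carries a different core from compound 2; how the two cores differ is not broken down here. Compound 4, `C[C@H](NC(=O)[C@H]1CC(F)(F)CC[C@@H]1c1ccccc1)c1ccccc1`, is not yet measured; it differs from compound 3 by hydrogen in place of hydroxy on a saturated chain carbon, two bonds along the chain from an amide-type nitrogen and an aromatic carbon, the same change as from compound 2 to compound 1, at the same place. Going by the values given here, because compound 2 to compound 1 gave an 8.0-fold lower number from compound 2 to compound 1 (0.90 log units; beyond the scatter), a step of similar size is expected here, a 7.9-fold lower number from compound 3 to compound 4 (0.90 log units; beyond the scatter), though only one earlier example supports this. Compound 4 is therefore estimated at 42000 nM, expected between 15000 nM and 120000 nM.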

Compound 4, solubility: 25000 nM
Beside the measured number, compound 4's estimate is 1.7-fold (0.23 log units) above it; the range from low to high includes it.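

In this assay the change from hydroxymethyl to methyl gave a 13-fold lower number from compound 3 to compound 4 (1.12 log units; beyond the scatter) on one core and an 8.0-fold lower number from compound 2 to compound 1 (0.90 log units; beyond the scatter) on the other core, so on both cores shown the number falls, by more than the usual scatter. Two cores are a small sample, so this does not show that the change would act the same way on any further core, nor does it settle whether the core alters the size of the step. Nothing available here explains why the number falls with this change.

From the compounds shown here alone, whether an amine, a carboxylic acid or a longer chain ending in hydroxy would behave like hydroxymethyl at this place stays open. Also open, going by these compounds, is how methyl and hydroxymethyl would compare on a third core.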